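The source may report more compounds than this note shows. Statements on the series, on what has been measured and on what is new or still open speak of the compounds shown alone.

Working notes on the series. Three sulfonamides sharing one core have been run in an assay on cells for inhibition of HSP60/HSP10 (Homo sapiens), with a stated time of 60 min; on this read-out lower numbers stand for stronger inhibition and higher numbers for weaker inhibition. Compound 1 `O=S(=O)(Nc1ccc(-c2nc3ccccc3o2)cc1)c1cccc(F)c1` gives 71000 nM. Compound 2 `O=S(=O)(Nc1ccc(-c2nc3ccccc3o2)cc1)c1ccc(Cl)s1` gives 31000 nM. Compound 3 `O=S(=O)(Nc1ccc(-c2nc3ccccc3o2)cc1)c1cccc(O)c1` gives 62000 nM. Among these three numbers compound 3 stands second highest; its nearest neighbour is compound 1, a difference within the scatter, and its furthest is compound 2, a difference that is also within the scatter.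

The next compound is compound 4 `O=S(=O)(Nc1ccc(-c2nc3ccccc3o2)cc1)c1cccc(Cl)c1`. Its change from compound 3 is chloro in place of hydroxy on an aromatic carbon, that is, a single heavy atom swapped for another on the ring that sits on the sulfonyl sulfur, with the donor and acceptor of the hydroxy lost.

Among the measured compounds shown here, two measured steps bear on it. For the measured compounds named here, the closest precedent is a 1.1-fold lower number from compound 1 to compound 3 (0.06 log units; within the scatter), a swap of one small substituent at the same place with no effect beyond the scatter. Going by the values given here, the only step that went beyond the scatter, a 2.3-fold lower number from compound 1 to compound 2 (0.36 log units; beyond the scatter), exchanged the whole ring rather than one substituent and so is a looser guide. On this basis the expected step from compound 3 to compound 4 is small, a 1.2-fold lower number from compound 3 to compound 4 (0.09 log units; within the scatter), likely within the scatter. For compound 4 the estimate in this assay is 50000 nM, with a range from 20000 nM to 120000 nM.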

Compound 4, half-maximal inhibitory concentration: 54000 nM
For compound 4 the middle estimate is 1.1-fold (0.03 log units) below the measured one; low and high end bracket the measured number.
By their numbers in this assay, from the lowest: compounds 2, 4, 3 and 1 (each within the scatter of the next, the first and the last beyond it).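

At this place on the six-membered aromatic ring of carbon only, meta to a large group, losing the hydrogen-bond donor and acceptor of the hydroxy leaves the number in this assay within the scatter, with a 1.1-fold lower number from compound 3 to compound 4 (0.06 log units; within the scatter), and chloro in place of fluoro gives a 1.3-fold lower number from compound 1 to compound 4 (0.12 log units; within the scatter), also within the scatter, so fluoro, hydroxy and chloro are not told apart here. The ring exchange now reads differently: with chlorine on both rings, a 1.7-fold higher number from compound 2 to compound 4 (0.24 log units; within the scatter) stays within the scatter, while the exchange involving 3-fluorophenyl, a 2.3-fold lower number from compound 1 to compound 2 (0.36 log units; beyond the scatter), lies beyond it, so a ring exchange at the sulfonyl sulfur does not by itself give a step beyond the scatter. No measurement on hand offers a reason for either reading.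

The compounds shown leave open whether an amine, a carboxylic acid or a longer chain at this place would give a step beyond the scatter in this assay. They also leave open whether chloro or hydroxy would read the same at another place on this ring, and whether the small differences seen here would hold on a changed core.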